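The source may report more compounds than this note shows. Statements on the series, on what has been measured and on what is new or still open speak of the compounds shown alone.

In a functional assay on A2780 cells (Homo sapiens) for cytotoxicity (a lower number here means a stronger inhibitor, a higher number a weaker inhibitor), three compounds built on a shared core have been measured so far. Compound 1 `CC(C)(C)C(=O)Nc1ncc(SCc2ncc(C(C)(C)C)o2)s1` gives 250 nM, the lowest of the three numbers. Compound 2 `CC(C)(C)c1cnc(CSc2cnc(NC(=O)OCc3ccccc3)s2)o1` gives 1040 nM, and compound 3 `CC(C)(C)c1cnc(CSc2cnc(NS(=O)(=O)c3ccccc3)s2)o1` gives 2860 nM.

The unmeasured compound 4 `CC(C)(C)c1cnc(CSc2cnc(NC(=O)Nc3ccc(F)cc3)s2)o1` differs from compound 1 in one place: (4-fluorophenyl)amino in place of tert-butyl on a carbonyl carbon. Going by the values given here, one measured step bears directly on this change. There, benzyloxy, which also brings an aromatic ring, took the place of the same tert-butyl, and the result was a 4.2-fold higher number from compound 1 to compound 2 (0.62 log units; beyond the scatter), a modest step. Compound 3 has no such carbonyl, so it offers only a looser comparison, though its 2860 nM also lies on the weaker side of compound 1. With a single direct step to go on, a similar move toward a weaker inhibitor seems the best guess, and the uncertainty is wide. In this assay the expected change is a 4.0-fold higher number from compound 1 to compound 4 (0.60 log units; beyond the scatter). For compound 4 the estimated value is 1000 nM, with an expected range from 300 nM to 3500 nM.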

Compound 4, half-maximal inhibitory concentration: 900 nM
For compound 4 the middle estimate is 1.1-fold (0.05 log units) above the measured one; the range from low to high includes it.
By their numbers in this assay, from the lowest: compound 1; then compounds 4 and 2 (each within the scatter of the next); then compound 3.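

In this assay, putting (4-fluorophenyl)amino in place of tert-butyl on this carbonyl carbon gives a 3.6-fold higher number from compound 1 to compound 4 (0.56 log units; beyond the scatter), so a second aromatic group also lands on the weaker side of compound 1. Exchanging benzyloxy for (4-fluorophenyl)amino gives a 1.2-fold lower number from compound 2 to compound 4 (0.06 log units; within the scatter), which is within the scatter, so this assay does not separate these two groups, and of the three groups seen on this carbonyl carbon, tert-butyl gives the lowest number. No measurement at hand gives a reason for these differences.

Still open, from the compounds shown here alone, is whether a different non-aromatic group on this carbonyl carbon, such as methyl or cyclopropyl, would give a number close to that of compound 1. Also open, going by these compounds, is whether phenylamino, without the fluorine, would give a number close to that of compound 4.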